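The compounds below may be only part of what the source reports. "The series", "measured", "known", "first", "only" and "open" are said of these compounds alone.

Working notes on the series. All compounds carry the same core; the variation sits on the saturated ring and on the substituent of the amide-type nitrogen. In an assay on HEK293 cells for inhibition of transient receptor potential cation channel subfamily M member 8 (Homo sapiens), read by FLIPR and calcium flux (on this read-out higher numbers stand for weaker inhibition and lower numbers for stronger inhibition), compound 1 `CCN(C(=O)c1ccccc1OCc1ccccc1)C1CCCNC1` gives 4860 nM. Compound 2 `NC1CCN(C(=O)c2ccccc2OCc2ccccc2)C1` reaches only the limit of this assay, > 10000 nM, so no number stands for it. Among the compounds with values here, compound 3 `CCCN(C(=O)c1ccccc1OCc1ccccc1)[C@@H]1CCC[C@H](N)C1` gives 1430 nM in this assay, the lower of the two numbers measured so far; compound 1 sits beyond the usual scatter above it. The value of compound 2 is a limit of > 10000 nM in this assay, at which 1 of the 3 values shown sits, and cannot be ranked.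

Compound 4 `N[C@H]1CCC[C@@H](N(CC2CC2)C(=O)c2ccccc2OCc2ccccc2)C1` differs from compound 3 by cyclopropyl in place of ethyl on a saturated chain carbon bound to an amide-type nitrogen. Within the data shown here, no pair of measured compounds shows a step of this kind, so the expectation rests on compound 3 alone. The step is expected to be small, most likely toward stronger inhibition but possibly within the scatter: a 1.4-fold lower number from compound 3 to compound 4 (0.16 log units; within the scatter). For compound 4 in this assay the estimate is 1000 nM, with a range from 400 nM to 3000 nM.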

Compound 4, antagonist equilibrium constant: 665 nM
The estimate for compound 4 lay 1.5-fold (0.18 log units) above the measured number; the measured number falls inside the stated range.
By their numbers in this assay, from the lowest: compound 4; then compound 3; then compound 1. At a limit, above all of these: compound 2.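

The first step read in the series falls at this place: in this assay, cyclopropyl in place of ethyl on a saturated chain carbon bound to an amide-type nitrogen gives a 2.2-fold lower number from compound 3 to compound 4 (0.33 log units; beyond the scatter) and so moves the number beyond the scatter, with the saturated ring held fixed. Compounds 1 to 3 differ from each other in more than one place and could not separate the substituent on this nitrogen from the ring; read one bond further out, the same change is propyl to cyclopropylmethyl, so a three-membered ring is accepted here without loss of inhibition. Nothing measured here gives a reason for the step.

On these data alone, whether cyclobutyl or a longer chain at this place would lower the number further stays open. Also open, as far as these compounds go, is whether the same change acts alike on the saturated ring of compound 1.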